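A few compounds are considered here, and "the series" means these few. Any claim that something is new, unique, unknown or untested is made for them only; others in the source may bear on it.

Measured compounds in a functional assay on MGC-803 cells (Homo sapiens) for inhibition, read by MTT assay, with a stated time of 72 h; on this read-out higher numbers stand for weaker inhibition and lower numbers for stronger inhibition:
compound 1 `Cc1cc(Nc2ccn(Cc3cccc4ccccc34)n2)n2nc(SCc3ccc(Br)cc3)nc2n1` — compound 1 gives 3240 nM
compound 2 `Cc1cc(Nc2cc(-c3ccc(Cl)cc3)[nH]n2)n2nc(SCc3ccc(Br)cc3)nc2n1` — compound 2 gives 2780 nM
compound 3 `Cc1cc(Nc2ccn(Cc3nc(C)c4ccccc4n3)n2)n2nc(SCc3ccc(Br)cc3)nc2n1` — compound 3 gives 960 nM

Compound 3 holds the lowest number of the three. Compound 2 sits nearest, with a number beyond the scatter above that of compound 3, and compound 1 furthest, also beyond the scatter. For the measured compounds named here, the one single-point step in the set is a 3.4-fold lower number from compound 1 to compound 3 (0.53 log units; beyond the scatter), a modest move toward stronger inhibition.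

Compound 4 `Cc1ccc(Cn2ccc(Nc3cc(C)nc4nc(SCc5ccc(Br)cc5)nn34)n2)cc1` is not yet measured. It differs from compound 3 as 4-methylphenyl in place of 4-methylquinazolin-2-yl on a saturated chain carbon bound to an aromatic nitrogen. Going by the values given here, this is the reverse sense of the one step known: from compound 1 to compound 3 a carbon-only bicyclic group was replaced by the 4-methylquinazolin-2-yl group and the number fell. In compound 4 that group is taken away again, this time for a single carbon-only ring, so the most direct reading is that the number drifts back up toward the region of compound 1 and compound 2. Among the compounds with values here, compound 2 carries a different substitution pattern and gives no step to compound 3, so it only marks where other variants land. The expected step is therefore a modest rise in the number, though a result within the scatter cannot be ruled out. For compound 4 the estimate is 2500 nM, between 1000 nM and 6500 nM, which corresponds to an expected step of a 2.6-fold higher number from compound 3 to compound 4 (0.42 log units; beyond the scatter).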

Compound 4, half-maximal inhibitory concentration: 7420 nM
Beside the measured number, compound 4's estimate is 3.0-fold (0.47 log units) below it; the measured number lies above the stated range.
By their numbers in this assay, from the lowest: compound 3; then compounds 2 and 1 (each within the scatter of the next); then compound 4.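

In this assay, the group on the saturated chain carbon bound to an aromatic nitrogen now has three members, and 4-methylphenyl in place of 4-methylquinazolin-2-yl gives a 7.7-fold higher number from compound 3 to compound 4 (0.89 log units; beyond the scatter). The number does not merely return to the level of the naphthalen-1-yl analogue: 4-methylphenyl in place of naphthalen-1-yl gives a 2.3-fold higher number from compound 1 to compound 4 (0.36 log units; beyond the scatter), so the three groups separate beyond the scatter, with 4-methylquinazolin-2-yl lowest, naphthalen-1-yl in the middle and 4-methylphenyl highest. The exchange in compound 4 removes one six-membered aromatic ring with 2 hetero atoms and leaves a single carbon-only ring, but nothing shown here explains why the number moves at this position.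

The exchange from compound 3 to compound 4 alters the ring count and the ring nitrogens together, so the share of each in the step remains unresolved. From the compounds shown here alone, it also remains open whether a single nitrogen-containing ring such as pyridin-2-yl would stay near compound 3 or near compound 4, and how an amine or a carboxylic acid would behave on the same chain carbon.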